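The compounds below may be only part of what the source reports. "The series", "measured", "known", "first", "only" and "open" are said of these compounds alone.

Compound 1 `Cc1nn(C)c2c1C(c1ccccc1)C(C#N)=C(N)O2`: 9100 nM
Compound 2 `Cn1nc(-c2ccccc2)c2c1OC(N)=C(C#N)C2c1ccccc1`: > 10000 nM (a limit)

Both compounds were tested in a functional assay on NCI-H2122 cells (Homo sapiens) for inhibition, read by microscopy, with a stated time of 10 days; a lower number here means a stronger inhibitor, a higher number a weaker inhibitor. Among the compounds with values here, compound 1, at 9100 nM, is the only compound here with an actual number. The result for compound 2 is a limit of the assay, not a number. Within the data shown here, the only measured step, an at least 1.0-fold higher number from compound 1 to compound 2 (0.04 log units; that floor lies within the scatter), is therefore just a floor, set by the limit of > 10000 nM in this assay, at which 1 of the 2 values shown sits. It also changes a different place in the molecule, so it offers little guidance for what comes next.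

Compound 3 `Cc1nn(C)c2c1C(c1ccc(-n3ccnc3)cc1)C(C#N)=C(N)O2` keeps the core of compound 1 and adds one group: 1H-imidazol-1-yl in place of hydrogen on an aromatic carbon. Among the measured compounds shown here, no measured step tests this change, so no shift beyond the scatter can be predicted in this assay, in either direction. The expected change is a 1.5-fold lower number from compound 1 to compound 3 (0.18 log units; within the scatter). Compound 3 is estimated at 6000 nM, with an expected range from 1200 nM to 20000 nM.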

Compound 3, half-maximal inhibitory concentration: 1700 nM
For compound 3 the middle estimate is 3.5-fold (0.55 log units) above the measured one; the measured number falls inside the stated range.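

In this assay, placing 1H-imidazol-1-yl on an aromatic carbon of the six-membered aromatic ring of carbon only, para to a large group, gives a 5.4-fold lower number from compound 1 to compound 3 (0.73 log units; beyond the scatter). This is the first step shown that can be read as a real change, and it shows that an added ring at this place can go with a stronger result. The earlier step to compound 2 changes a different place and cannot be read: the limit of > 10000 nM in this assay, at which 1 of the 3 values shown sits.

The compounds shown leave open whether this particular ring matters or whether another group at the same place, such as an amine or a carboxylic acid, would give a similar shift. They also do not tell why the number falls.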